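Pyridin-2-yl for Methylcarbamoyl: Expected Oral Exposure in Monkey

The source may hold more compounds than are shown below. What is called first, only, known or untested is meant among the compounds shown, and "the series" means these compounds.

Measured compounds:
Compound 1, `CCCCN(c1nc2c(C(=O)NC)cccc2o1)[C@H](C)c1ccc(-c2ccccc2-c2nnn[nH]2)cc1`: 19.7 nM
Compound 2, `CCCCN(c1nc2c(C(=O)O)cccc2o1)[C@H](C)c1ccc(-c2cc(Cl)ccc2-c2nc(=O)o[nH]2)cc1`: 677 nM

In an ADME assay on the whole organism (Macaca fascicularis) for pharmacokinetics, read by LC-MS, using cassette dosing, at a dose of 1 mg/kg by the oral route (on this read-out lower numbers stand for lower exposure and higher numbers for higher exposure at the dose given), compound 1 gives 19.7 nM, the lowest of the two numbers seen. Going by the values given here, compound 2, which differs from it in several places at once, gives 677 nM in this assay, a gap that lies beyond the scatter; with no single-point step between them, nothing more can be drawn from the pair than what these two values show.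

Compound 3, `CCCCN(c1nc2c(-c3ccccn3)cccc2o1)[C@H](C)c1ccc(-c2ccccc2-c2nnn[nH]2)cc1`, has not yet been measured. It differs from compound 1 in one place: pyridin-2-yl in place of methylcarbamoyl on an aromatic carbon. The new group sits on an aromatic carbon of a six-membered aromatic ring of carbon only, part of a fused system of two rings, ortho to a fused ring and meta to a fused ring. Among the compounds with values here, no comparable single-point change is among the measured data, so there is no step to anchor the expectation.

The step from compound 1 to compound 3 in this assay is estimated at a 1.5-fold higher number from compound 1 to compound 3 (0.18 log units; within the scatter), a change not expected to go beyond the scatter in either direction. Compound 3 is therefore expected to give about 30 nM in this assay, within a range from 6 nM to 150 nM.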

Compound 3, maximal plasma concentration: 124 nM
Compound 3: the middle estimate sits 4.1-fold (0.62 log units) below what was measured; measured number inside the range.
By their numbers in this assay, from the lowest: compound 1; then compound 3; then compound 2.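

In this assay, going by these compounds alone, the exchange of methylcarbamoyl for pyridin-2-yl on this aromatic carbon, ortho to a fused ring and meta to a fused ring, gives a 6.3-fold higher number from compound 1 to compound 3 (0.80 log units; beyond the scatter) and is the first single-place change, showing that maximal plasma concentration responds to what sits at this position. The step also shows that the position accepts a six-membered aromatic ring with no loss of oral exposure, although the change swaps a group with no ring and a hydrogen-bond donor for a larger one with a ring and no such donor, and this single step cannot tell those differences apart. Nothing available here accounts for the higher number.

On these data alone, whether the rise depends on the ring nitrogen, on the ring itself or on the departure of the amide hydrogen remains open, and phenyl, pyridin-3-yl and dimethylcarbamoyl at this carbon would bear directly on that. Compound 2 carries a carboxylic acid at this place but differs in several places at once, so the compounds shown do not isolate the effect of that group here.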